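A Benzoyl Group in Place of Methoxy on Compound 2

This account rests on a few compounds, and the source may have more. Where it says the series, first, only, none or still open, it means among the compounds named here.

Compound 2 `C=CCc1ccc(OCc2cn(-c3ccc(OC)cc3)nn2)c(O)c1` gives the highest of the three numbers in a functional assay on HepG2 cells (Homo sapiens) for inhibition, read by MTT assay, with a stated time of 72 h, tested at 30 uM (a higher number here means more inhibition of growth at the concentration tested, a lower number less inhibition of growth), namely 15.4%. Compound 1 `C=CCc1ccc(OCc2cn(-c3ccc(C#N)cc3)nn2)c(O)c1` gives 1.5% and compound 3 `C=CCc1ccc(OCc2cn(-c3ccccc3CO)nn2)c(O)c1` gives 4.2%. The step of a number 13.9 percentage points higher from compound 1 to compound 2 (beyond the scatter) and the step of a number 11.2 percentage points lower from compound 2 to compound 3 (beyond the scatter) are both modest, while a number 2.7 percentage points higher from compound 1 to compound 3 (within the scatter) stays within the scatter. Compound 4 `C=CCc1ccc(OCc2cn(-c3ccc(C(=O)c4ccccc4)cc3)nn2)c(O)c1` carries benzoyl in place of methoxy on an aromatic carbon. Within the data shown here, only the step from compound 1 to compound 2 concerns the same aromatic carbon, and there cyano was exchanged for methoxy, so it offers limited guidance for a benzoyl group. The step of a number 7.4 percentage points lower from compound 2 to compound 4 (within the scatter) is expected to be modest and downward, since compound 2 is the highest and the other two sit lower. For compound 4 the estimate is 8%, in a range from 0% to 25%.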

Compound 4, percent growth inhibition at one concentration: 14.8%
Beside the measured number, compound 4's estimate is 6.8 percentage points below it, within the range that was stated.
By their numbers in this assay, from the lowest: compounds 1 and 3 (each within the scatter of the next); then compounds 4 and 2 (each within the scatter of the next).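

In this assay, benzoyl in place of methoxy gives a number 0.6 percentage points lower from compound 2 to compound 4 (within the scatter), so at this position, para to a large group, a group of 8 heavy atoms with its own aromatic ring cannot be told apart from methoxy with 2. Benzoyl in place of cyano gives a number 13.3 percentage points higher from compound 1 to compound 4 (beyond the scatter), so cyano now stands apart from two different groups at this carbon, not one. Nothing available explains this result. As far as these compounds go, what an amine, a carboxylic acid or a longer chain would give on this carbon remains open.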